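Isopropyl to Carboxylic Acid on the Aryl Ring of a Urea

A few compounds are considered here, and "the series" means these few. Any claim that something is new, unique, unknown or untested is made for them only; others in the source may bear on it.

Three compounds have been measured in an assay on microsomes for inhibition of acyl-CoA:cholesterol acyltransferase (Oryctolagus cuniculus); a lower number here means a stronger inhibitor, a higher number a weaker inhibitor:
compound 1, `CC(C)c1ccc(C2(CNC(=O)Nc3c(C(C)C)cccc3C(C)C)CCCC2)cc1`, gives 48 nM
compound 2, `CC(C)c1cccc(C(C)C)c1NC(=O)NCC1(c2ccc(C(F)(F)F)cc2)CCCC1`, gives 66 nM
compound 3, `CC(C)c1cccc(C(C)C)c1NC(=O)NCC1(c2ccc(NCCO)cc2)CCCC1`, gives 25 nM

Compound 1 sits second highest of these three numbers. Its two neighbours differ only in the group on the aryl ring attached to the saturated ring: the step of a 1.4-fold higher number from compound 1 to compound 2 (0.14 log units; within the scatter) and the step of a 1.9-fold lower number from compound 1 to compound 3 (0.28 log units; within the scatter); a third step, a 2.6-fold lower number from compound 2 to compound 3 (0.42 log units; beyond the scatter), is modest. Compound 4, `CC(C)c1cccc(C(C)C)c1NC(=O)NCC1(c2cccc(C(=O)O)c2)CCCC1`, changes the same aryl ring as these: 3-carboxyphenyl in place of 4-isopropylphenyl on a saturated ring carbon. Both measured changes on that ring left the number little moved, so for compound 4 a step of a 1.7-fold higher number from compound 1 to compound 4 (0.22 log units; within the scatter) is expected, with perhaps a slight shift to a higher number. The estimate for compound 4 is therefore 80 nM, within a range of 25 nM to 250 nM.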

Compound 4, half-maximal inhibitory concentration: 620 nM
For compound 4 the middle estimate is 7.8-fold (0.89 log units) below the measured one, and the stated range ends below it.
By their numbers in this assay, from the lowest: compounds 3, 1 and 2 (each within the scatter of the next, the first and the last beyond it); then compound 4.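

Among the compounds shown here, the aryl ring on the saturated ring carbon proves less tolerant than the earlier compounds suggested: this assay shows a 13-fold higher number from compound 1 to compound 4 (1.11 log units; beyond the scatter) for the change to 3-carboxyphenyl, together with a 25-fold higher number from compound 3 to compound 4 (1.39 log units; beyond the scatter) and a 9.4-fold higher number from compound 2 to compound 4 (0.97 log units; beyond the scatter) in the matching comparisons. Unlike the earlier changes on this ring, this one sets a compound clearly apart from all the others. No measurement shown accounts for this loss.

Compound 4 changes both the group and where it sits on the ring, so the compounds shown do not separate those two changes. They also leave open how a methyl ester or a primary amide would compare with the carboxylic acid.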